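Indazole series: phenyl for isopropylamino at the aromatic carbon

This account rests on a few compounds, and the source may have more. Where it says the series, first, only, none or still open, it means among the compounds named here.

Going by the values given here, compound 2 `CC(C)Nc1ccc2c(-c3cnn(C)c3)n[nH]c2c1` sits second highest of the three numbers so far in an assay on isolated protein for inhibition of tyrosine-protein kinase receptor UFO (Homo sapiens), with a stated time of 1.5 h (on this read-out higher numbers stand for weaker inhibition and lower numbers for stronger inhibition), giving 46600 nM. Its nearest neighbour is compound 3 `Cn1cc(-c2n[nH]c3ccc(N[C@H]4CCNC4)cc23)cn1`, which in this assay gives 239000 nM, a number beyond the scatter above it. The furthest is compound 1 `N#Cc1ccc(-n2cc(-c3n[nH]c4cc(Cl)c(N[C@@H]5CCNC5)cc34)cn2)cc1`, which in this assay gives 700 nM, far below compound 2 and well beyond the scatter. No pair among these three differs in a single place, so no single-point step is available from the measured set.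

Compound 4 `Cn1cc(-c2n[nH]c3cc(-c4ccccc4)ccc23)cn1` has not yet been measured in this assay. It differs from compound 2 by phenyl in place of isopropylamino on an aromatic carbon. Among the compounds with values here, nothing among the measured compounds isolates this exchange, so the direction of the step rests on expectation only. Compound 4 is expected to land close to compound 2, with the expected step from compound 2 to compound 4 being a 1.6-fold lower number from compound 2 to compound 4 (0.19 log units; within the scatter), small and not clearly beyond the scatter. For compound 4 the expected value in this assay is 30000 nM, with a range from 8000 nM to 120000 nM.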

Compound 4, half-maximal inhibitory concentration: 12300 nM
Estimate against measurement, compound 4: 2.4-fold (0.39 log units) above; measured number inside the range.
By their numbers in this assay, from the lowest: compound 1; then compound 4; then compound 2; then compound 3.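

Going by these compounds alone, this is the first single-place comparison. Compound 4 replaces the isopropylamino group, which has a hydrogen-bond donor and acceptor, with a phenyl that has neither, and in this assay the exchange gives a 3.8-fold lower number from compound 2 to compound 4 (0.58 log units; beyond the scatter) as a modest step beyond the scatter. At this aromatic carbon, then, the nitrogen-linked group is not required to hold the level of inhibition seen with compound 2, and a six-membered aromatic ring of carbon only is tolerated.

Going by these compounds, it remains open whether a pyridyl ring, a phenyl carrying a nitrile or a chloro group, or a saturated ring amine such as pyrrolidinylamino at this carbon would lower the number further. No measurement on hand says why the number falls with this exchange.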